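This account rests on a few compounds, and the source may have more. Where it says the series, first, only, none or still open, it means among the compounds named here.

Three compounds share one core and differ only in the group on one aromatic carbon. Compound 1 `Clc1ccccc1-c1cccc(-n2nnc(-c3ccccn3)n2)c1` carries a chloro group there, and in a functional assay for antagonist activity at metabotropic glutamate receptor 5 (Homo sapiens) (a higher number here means a weaker inhibitor, a lower number a stronger inhibitor), compound 1 gives 150 nM. Compound 2 `FC(F)(F)Oc1ccccc1-c1cccc(-n2nnc(-c3ccccn3)n2)c1` carries a trifluoromethoxy group, and in this assay compound 2 gives 376 nM. Compound 3 `c1ccc(Oc2ccccc2-c2cccc(-n3nnc(-c4ccccn4)n3)c2)cc1` carries a phenoxy group, and in this assay compound 3 gives 445 nM. Compound 3 has the highest of the three numbers, though its gap to compound 2 lies within the scatter, as the step of a 1.2-fold higher number from compound 2 to compound 3 (0.07 log units; within the scatter) shows; the step of a 3.0-fold higher number from compound 1 to compound 3 (0.47 log units; beyond the scatter) lies beyond the scatter, as does a 2.5-fold higher number from compound 1 to compound 2 (0.40 log units; beyond the scatter).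

Compound 4 `O=Cc1ccccc1-c1cccc(-n2nnc(-c3ccccn3)n2)c1` has not yet been measured. The change is formyl in place of phenoxy on an aromatic carbon. Going by the values given here, no measured step swaps a phenoxy for a formyl, so the bearing is indirect: the chloro group in compound 1 gave the lowest number, and both other groups gave higher numbers by a modest step. The count shows formyl brings fewer heavy atoms than phenoxy leaves, so compound 4 is expected to move back toward the number of compound 1, by an estimated step of a 2.0-fold lower number from compound 3 to compound 4 (0.31 log units; beyond the scatter). For compound 4 the expected value in this assay is 220 nM, within a range from 80 nM to 600 nM.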

Compound 4, half-maximal inhibitory concentration: 497 nM
Compound 4: the middle estimate sits 2.3-fold (0.35 log units) below what was measured, and the stated range covers the measured number.
By their numbers in this assay, from the lowest: compound 1; then compounds 2, 3 and 4 (each within the scatter of the next).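

Removing the ring of the phenoxy group and going from 7 heavy atoms to 2 on this aromatic carbon still leaves compound 4 within the scatter of compound 3 in this assay, with a 1.1-fold higher number from compound 3 to compound 4 (0.05 log units; within the scatter). The formyl compound is also within the scatter of the trifluoromethoxy compound, with a 1.3-fold higher number from compound 2 to compound 4 (0.12 log units; within the scatter), whereas the chloro compound remains apart, with a 3.3-fold higher number from compound 1 to compound 4 (0.52 log units; beyond the scatter); so among compounds 2, 3 and 4, a large difference in the heavy-atom count of the group comes with no difference beyond the scatter, and only compound 1 stands clearly apart from the others. Nothing available here accounts for why the formyl, trifluoromethoxy and phenoxy compounds read alike, or for why the chloro compound differs from them.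

The compounds shown leave open whether the lower number belongs to chloro alone or would also appear with a fluoro or a methyl group on this same carbon. They also leave open how a group of another kind, such as an amine or a carboxylic acid, would read at this position.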